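The source may report more compounds than this note shows. Statements on the series, on what has been measured and on what is new or still open speak of the compounds shown alone.

Measured so far in a functional assay on T-24 cells (Homo sapiens) for antiproliferative activity, read by MTT assay, with a stated time of 72 h; on this read-out lower numbers stand for stronger inhibition and higher numbers for weaker inhibition:
- compound 1 `CC(C)NC(=N)NC(=N)Nc1ccc(F)c(F)c1` gives 45000 nM
- compound 2 `CCN(CC)C(=N)NC(=N)Nc1ccc(F)c(F)c1` gives 44800 nM
- compound 3 `CCCCCCCNC(=N)NC(=N)Nc1ccc(F)c(F)c1` gives 4300 nM

Compound 3 has the lowest number of the three, so it is the strongest inhibitor in this small set. The next compound, compound 4 `N=C(NC(=N)NC1CCCC1)Nc1ccc(F)c(F)c1`, keeps the shared core but carries cyclopentyl in place of heptyl on an amine nitrogen.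

Two measured steps offer guidance. The more relevant one is heptyl in place of isopropyl on an amine nitrogen, which gave a 10-fold lower number from compound 1 to compound 3 (1.02 log units; beyond the scatter) and counts as a large step. The other, diethylamino in place of isopropylamino, gave a 1.0-fold lower number from compound 1 to compound 2 (0.00 log units; within the scatter), so that swap left the read-out within the scatter. Neither step involves a ring on this nitrogen, so the data offer only an indirect guide. Among these compounds, only the one with the heptyl chain stands apart, so losing that chain may lose much of its advantage, perhaps not all of it. The expected change is a 4.7-fold higher number from compound 3 to compound 4 (0.67 log units; beyond the scatter), a clear move towards weaker inhibition. Compound 4 is estimated at about 20000 nM, with an expected range of 8000 nM to 50000 nM.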

Compound 4, half-maximal inhibitory concentration: 24900 nM
For compound 4 the middle estimate is 1.2-fold (0.10 log units) below the measured one; measured number inside the range.
By their numbers in this assay, from the lowest: compound 3; then compounds 4, 2 and 1 (each within the scatter of the next).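

In this assay, a ring on this amine nitrogen does not keep what the heptyl chain gave, and the step to cyclopentyl is clearly beyond the scatter (a 5.8-fold higher number from compound 3 to compound 4 (0.76 log units; beyond the scatter)). Against the two groups that gave the weaker numbers, the ring brings no change that stands out from the scatter, either in place of isopropyl (a 1.8-fold lower number from compound 1 to compound 4 (0.26 log units; within the scatter)) or in place of diethylamino (a 1.8-fold lower number from compound 2 to compound 4 (0.26 log units; within the scatter)), so compound 4 sits with compound 1 and compound 2, while compound 3 alone stands apart. The data at hand offer no measurement that explains this difference.

Heptyl and cyclopentyl differ both in their count of carbons and in having a ring, so these compounds cannot separate the two changes; an open pentyl chain, which has the same count of carbons as cyclopentyl, or a cycloheptyl ring, which has the same count as heptyl, would pull them apart. As far as these compounds go, it also stays open whether the number keeps falling with a longer chain such as decyl, or whether heptyl is already near the best length.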